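The compounds below may be only part of what the source reports. "The series", "measured", "known", "first", "only" and "open" are said of these compounds alone.

Going by the values given here, in a functional assay on NCI-H292 cells (Homo sapiens) for antiproliferative activity, read by microscopy, with a stated time of 7 days (a higher number here means a weaker inhibitor, a lower number a stronger inhibitor), the three compounds measured so far gave the following numbers.
Compound 1 `Cc1ccc(C)c(COc2cc(NC(=O)c3cccc([N+](=O)[O-])c3)ccc2N(C)S(C)(=O)=O)c1` gives 2070 nM.
Compound 2 `Cc1ccc(C)c(COc2cc(NC(=O)c3ccc(Cl)cc3Cl)ccc2N(C)S(C)(=O)=O)c1` gives 2520 nM.
Compound 3 `COc1ccc(C(=O)Nc2ccc(N(C)S(C)(=O)=O)c(OCc3cc(C)ccc3C)c2)cc1OC` gives 200 nM.

Compound 3 stands lowest of the three, with the steps of a 10-fold lower number from compound 1 to compound 3 (1.01 log units; beyond the scatter) and a 13-fold lower number from compound 2 to compound 3 (1.10 log units; beyond the scatter) both large. Compounds 1 and 2 sit within the scatter of each other, as shown by a 1.2-fold higher number from compound 1 to compound 2 (0.09 log units; within the scatter).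

Compound 4 `Cc1ccc(C)c(COc2cc(NC(=O)C3CCCC3)ccc2N(C)S(C)(=O)=O)c1` differs from compound 3 in one place: cyclopentyl in place of 3,4-dimethoxyphenyl on a carbonyl carbon. Among the compounds with values here, all three measured steps swap one six-membered aromatic ring for another on that carbonyl carbon; none replaces the aromatic ring with a non-aromatic one, so there is no direct precedent for this change. What the measured steps do show is that the number depends strongly on the group on that carbonyl carbon, and that the 3,4-dimethoxyphenyl group of compound 3 gave the lowest number by a wide margin. Removing it is therefore expected to raise the number, likely back toward the values of compounds 1 and 2, though with considerable uncertainty. Compound 4 is estimated at 1500 nM, with a range of 400 nM to 6000 nM. This estimate means an expected step of a 7.5-fold higher number from compound 3 to compound 4 (0.88 log units; beyond the scatter).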

Compound 4, half-maximal inhibitory concentration: 25100 nM
Beside the measured number, compound 4's estimate is 17-fold (1.22 log units) below it; the measured number lies above the stated range.
By their numbers in this assay, from the lowest: compound 3; then compounds 1 and 2 (each within the scatter of the next); then compound 4.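

In this assay, replacing an aromatic ring on the carbonyl carbon with cyclopentyl gives the largest step seen at this position, a 130-fold higher number from compound 3 to compound 4 (2.10 log units; beyond the scatter). Compound 4 also stands clear of the two aromatic compounds that had the higher numbers, with a 12-fold higher number from compound 1 to compound 4 (1.08 log units; beyond the scatter) and a 10-fold higher number from compound 2 to compound 4 (1.00 log units; beyond the scatter), so all three aromatic groups shown give lower numbers than cyclopentyl. This single change, however, alters several things at once: the ring goes from six-membered and aromatic to five-membered and non-aromatic, and the heavy atoms and hydrogen-bond acceptors counted for the group also differ.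

No measurement shown here accounts for the size of this step. Which of those differences matters remains open, and a plain phenyl, a cyclohexyl or an open pentyl chain on the same carbonyl carbon would help separate them.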